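Methoxy in Place of Methyl: One Analogue Awaits Measurement

The compounds below may be only part of what the source reports. "The series", "measured", "known", "first", "only" and "open" are said of these compounds alone.

Compound 1 `Cc1ccc(-c2cn(CCCO)nn2)cc1`: in a functional assay on B16 cells (Mus musculus) for cytotoxicity, read by MTT assay, with a stated time of 48 h (on this read-out lower numbers stand for stronger inhibition and higher numbers for weaker inhibition), compound 1 gives > 100000 nM, which is a limit of the assay rather than a number.
Compound 2 `COc1ccc(C(O)c2cn(C[C@H]3COC(C)(C)O3)nn2)c(OC)c1OC`: in this assay compound 2 gives > 100000 nM, likewise a limit of the assay.

Compound 1 therefore stands at the edge of what this assay reports, and compound 2 stands there as well; the two cannot be ordered against each other, since both sit at the limit of > 100000 nM in this assay, at which 2 of the 2 values shown sit. Compound 3 `COc1ccc(-c2cn(CCCO)nn2)cc1` has not yet been measured. It differs from compound 1 by a single change: methoxy in place of methyl on an aromatic carbon. For the measured compounds named here, no pair of measured compounds shows what such a change does in this setting. Because compound 1 and compound 2 both sit at the limit of > 100000 nM in this assay, at which 2 of the 2 values shown sit, compound 3 is expected to remain there too, and the step is estimated as a step that the limit leaves unreadable from compound 1 to compound 3, nothing beyond the scatter. Compound 3 is thus expected to give about 150000 nM in this assay, within 30000 nM to 1000000 nM, most probably reported again only as a limit.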

Compound 3, half-maximal inhibitory concentration: > 100000 nM
Compound 3: a limit, no number; the forecaster's own chance of this, stated with the estimate: 85%; the middle value is on the limit's open side.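

For the compounds shown here, compound 3 gives > 100000 nM in this assay, which is a limit and not a number, so no step between compound 1 and compound 3 can be read: the limit of > 100000 nM in this assay, at which 3 of the 3 values shown sit.

The compounds shown leave open what methoxy in place of methyl on an aromatic carbon does in this assay.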